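The source may report more compounds than this note shows. Statements on the series, on what has been measured and on what is new or still open speak of the compounds shown alone.

Working notes on the series. Compound 1 `COc1cc(-c2cc(/C=C/C(=O)c3ccc(N)cc3)[nH]n2)cc(OC)c1OC` gives 2770 nM in a functional assay on U-251 cells (Homo sapiens) for inhibition, read by sulforhodamine B assay, with a stated time of 48 h (on this read-out lower numbers stand for stronger inhibition of growth and higher numbers for weaker inhibition of growth), which is the second highest of the three numbers: compound 2 `COc1ccc(-c2cc(/C=C/C(=O)c3ccc(OC)c(OC)c3)[nH]n2)cc1` gives 2340 nM in this assay, within the scatter of compound 1, while compound 3 `COc1cc(-c2cc(/C=C/C(=O)c3ccc(Cl)c(Cl)c3)[nH]n2)cc(OC)c1OC` gives 80500 nM. Going by the values given here, the one step measured in a single place is a 29-fold higher number from compound 1 to compound 3 (1.46 log units; beyond the scatter), a change on the carbonyl-side ring.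

Compound 4 `COc1ccc(-c2cc(/C=C/C(=O)c3ccc(N)cc3)[nH]n2)cc1OC` differs from compound 1 by hydrogen in place of methoxy on an aromatic carbon. Among the compounds with values here, no measured step touches this ring; the replacement on the carbonyl carbon in the step from compound 1 to compound 3 concerns the other ring and does not bear on it. Within the data shown here, the only hint is compound 2, which carries a single methoxy on the pyrazole-side ring and in this assay gives a number within the scatter of compound 1. On that basis no step beyond the scatter is expected in this assay from compound 1 to compound 4, in either direction; the expected step is a 1.1-fold higher number from compound 1 to compound 4 (0.03 log units; within the scatter). Compound 4 is therefore estimated at 3000 nM in this assay, with a range from 1200 nM to 8000 nM.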

Compound 4, concentration for total growth inhibition: 3660 nM
Beside the measured number, compound 4's estimate is 1.2-fold (0.09 log units) below it; low and high end bracket the measured number.
By their numbers in this assay, from the lowest: compounds 2, 1 and 4 (each within the scatter of the next); then compound 3.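

In this assay, going by these compounds alone, a 1.3-fold higher number from compound 1 to compound 4 (0.12 log units; within the scatter) is the first measured step at this position, a place ortho to a methoxy group and meta to a large group. With hydrogen in place of methoxy the number stays within the scatter, so this methoxy group is not required to keep the growth inhibition of compound 1 at its level, at least with 4-aminophenyl on the carbonyl carbon. The step is much smaller than a 29-fold higher number from compound 1 to compound 3 (1.46 log units; beyond the scatter) on the carbonyl side. No measured data are available to explain the result.

The compounds shown leave open whether an amine, a hydroxyl or a longer chain such as ethoxy at this place would also stay within the scatter. They also leave open whether hydrogen in place of methoxy would stay within the scatter with 3,4-dichlorophenyl on the carbonyl carbon.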